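Shifting the Furan Attachment Point in Compound 1

The compounds below may be only part of what the source reports. "The series", "measured", "known", "first", "only" and "open" are said of these compounds alone.

Compound 1 `Oc1ccc(-c2cc(-c3ccco3)cc(-c3ccccc3O)n2)cc1` was tested in a functional assay on T47D cells (Homo sapiens) for cytotoxicity, read by CCK-8 assay; a higher number here means a weaker inhibitor, a lower number a stronger inhibitor. In that assay compound 1 gives only a limit, > 50000 nM (the limit of > 50000 nM in this assay, at which 1 of the 2 values shown sits). Compound 2 `Oc1ccc(-c2cc(-c3ccco3)cc(-c3ccc(O)cc3)n2)cc1` gives 21100 nM in this assay. The measured step of an at least 2.3-fold lower number from compound 1 to compound 2 (0.37 log units; beyond the scatter) concerns the hydroxyphenyl group, not the furan. Compound 3 `Oc1ccc(-c2cc(-c3ccoc3)cc(-c3ccccc3O)n2)cc1` differs from compound 1 by furan-3-yl in place of furan-2-yl on an aromatic carbon. Among the measured compounds shown here, no measured step touches this change, so in this assay no shift beyond the scatter is expected. Compound 3 is therefore expected to give about 60000 nM, between 25000 nM and 200000 nM, most likely again only a limit. The step this estimate implies, a step that the limit leaves unreadable from compound 1 to compound 3, is expected to stay within the scatter.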

Compound 3, half-maximal inhibitory concentration: > 50000 nM
Compound 3: no number, only a limit (the forecaster's own chance of this, stated with the estimate: 70%); the middle value lies beyond the limit too.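

No step can be read between compound 1 and compound 3 in this assay, because each gives only a limit, not a number: the limit of > 50000 nM in this assay, at which 2 of the 3 values shown sit. The compounds shown leave open whether furan-3-yl and furan-2-yl differ at all in cytotoxicity.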